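Swapping acetyl for dimethylamino on an inactive core

The source may report more compounds than this note shows. Statements on the series, on what has been measured and on what is new or still open speak of the compounds shown alone.

Measured so far:
compound 1, `COc1cc(C)cc(-c2c(-c3ccnc(-c4ccc(C(C)=O)cc4)c3)cnn2CC#N)c1`, gives > 100000 nM in a functional assay on SNB-19 cells (Homo sapiens) for inhibition, read by sulforhodamine B assay, with a stated time of 48 h; a lower number here means a stronger inhibitor of growth, a higher number a weaker inhibitor of growth.
compound 2, `COc1cc(C)cc(-c2nn(CC#N)cc2-c2ccnc(-c3ccc(N(C)C)cc3)c2)c1`, gives > 100000 nM in this assay.

Both numbers are limits of the test rather than true values. For compound 1 the result > 100000 nM means that no growth inhibition was reached within the range tested. Compound 2 likewise stands at its own limit, > 100000 nM. So compound 1 cannot be placed above or below anything shown; it simply sits at the limit of > 100000 nM in this assay, at which 2 of the 2 values shown sit.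

Compound 3, `COc1cc(C)cc(-c2c(-c3ccnc(-c4ccc(N(C)C)cc4)c3)cnn2CC#N)c1`, is to be measured. It arises from compound 1 by one change, dimethylamino in place of acetyl on an aromatic carbon. Going by the values given here, with no step between measured compounds, no measured precedent for this change exists here. Since compound 1 already shows no measurable effect at > 100000 nM, the step that the limit leaves unreadable from compound 1 to compound 3 is expected to be none beyond the scatter. Compound 3 is therefore estimated at 150000 nM, within 40000 nM to 500000 nM, most likely again reported only as a limit.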

Compound 3, concentration for total growth inhibition: > 100000 nM
Compound 3: no number, only a limit (the forecaster's own chance of this, stated with the estimate: 80%); the middle value does not contradict the limit.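

In this assay compound 3 gives > 100000 nM, which is a limit and not a true number. Going by these compounds alone, no step from compound 1 to compound 3 can therefore be read, since neither compound has a true number: the limit of > 100000 nM in this assay, at which 3 of the 3 values shown sit. On these data alone, what stays open is how 4-acetylphenyl and 4-(dimethylamino)phenyl would compare on a core that gives a true number.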